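Pyridine for Pyrimidine on an Inactive Dopamine Ligand

The source may hold more compounds than are shown below. What is called first, only, known or untested is meant among the compounds shown, and "the series" means these compounds.

Measured compounds:
compound 1 `Cc1cccc(NC(=O)CCN2CCN(c3ncccn3)CC2)c1`: "not active" (no number reported)
compound 2 `Cc1cccc(NC(=O)CN2CCN(c3ncccn3)CC2)c1`: 24.7%

In an assay on cells for agonist activity at D(4) dopamine receptor (Homo sapiens), read by luminescence and beta-arrestin recruitment, with a stated time of 90 min (on this read-out higher numbers stand for larger maximal responses and lower numbers for smaller maximal responses), compound 1 is recorded as "not active" (no number reported), so no number fixes where it stands; it gave no measurable maximal response. The related compound 2 reaches 24.7% in this assay, a small maximal response. Compound 3 `Cc1cccc(NC(=O)CCN2CCN(c3ccccn3)CC2)c1` is compound 1 with a single change: pyridin-2-yl in place of pyrimidin-2-yl on an amine nitrogen in a ring. Among the compounds with values here, no pair of measured compounds differs only in this place, so nothing here shows what the exchange of a ring with two hetero atoms for one with one hetero atom does by itself. Since compound 1 shows no response at all, a step in this assay that is at most slightly upward, and quite possibly none beyond the scatter, is expected. Compound 3 is therefore estimated at 12%, within a range from 0% to 35%, with a real chance that it too is reported only as not active.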

Compound 3, largest response reached (Emax), in percent of the reference or control that the assay uses: "not active" (no number reported)
No number was reported for compound 3; no gap can be computed for the estimate.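

Within the data shown here, compound 1 and compound 3 are both recorded without a number, so no step between them can be read, and no supporting evidence bears on this result. The compounds shown leave open what replacing pyrimidin-2-yl with pyridin-2-yl does by itself.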